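A few compounds are considered here, and "the series" means these few. Any claim that something is new, unique, unknown or untested is made for them only; others in the source may bear on it.

Working notes on the series. Compound 1 `CC1=C(C(=O)OC(C(F)(F)F)C(F)(F)F)C(c2ccsc2)NC(=O)N1` in an assay on HEK293 cells for displacement of a labelled ligand from adenosine receptor A2b (Homo sapiens), read by radioligand binding, with a stated time of 30 min, tested at 1 uM (on this read-out lower numbers stand for less inhibition and higher numbers for more inhibition at the one concentration tested (going by the name of the read-out)), gives 1%. Compound 2 `CC1=C(C(=O)OCC(F)(F)F)C(c2ccsc2)NC(=O)N1` differs from compound 1 by hydrogen in place of trifluoromethyl on a saturated chain carbon bound to an oxygen next to a carbonyl group and a saturated chain carbon; in this assay compound 2 gives 24%, a step of a number 23 percentage points higher from compound 1 to compound 2 (beyond the scatter). Compound 3 `CC1=C(C(=O)OC(C(F)(F)F)C(F)(F)F)C(c2cccs2)NC(=O)N1` carries the other core, the difference being (thiophen-2-yl in place of thiophen-3-yl on a saturated ring carbon); in this assay compound 3 gives 1%, which is no change at the digits printed from compound 1 to compound 3 (within the scatter), so compound 1 and compound 3 sit together at the low end of the three numbers and the core swap on its own leaves the read-out where it was.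

Compound 4 `CC1=C(C(=O)OCC(F)(F)F)C(c2cccs2)NC(=O)N1` is not yet measured. It stands to compound 3 exactly as compound 2 stands to compound 1: the change is hydrogen in place of trifluoromethyl on a saturated chain carbon bound to an oxygen next to a carbonyl group and a saturated chain carbon, and the place is described in the same words for both pairs, so it is the same change made on the other core. Among the compounds with values here, the only guide to its size is the earlier instance, a number 23 percentage points higher from compound 1 to compound 2 (beyond the scatter), and the core swap no change at the digits printed from compound 1 to compound 3 (within the scatter) gives no sign that the second core responds differently. The step from compound 3 to compound 4 is therefore expected to be a number 23 percentage points higher from compound 3 to compound 4 (beyond the scatter), close to the earlier one. Because it rests on a single pair, the range is kept wide. Compound 4 is estimated to give 24% in this assay, with the expected range running from 5% to 45%.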

Compound 4, a percentage reported as inhibition, at one concentration (the size of the read-out at that concentration, not a potency): 1%
Beside the measured number, compound 4's estimate is 23 percentage points above it, outside the stated range (below it).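

In this assay the change of trifluoromethyl to hydrogen gives no change at the digits printed from compound 3 to compound 4 (within the scatter) and so does not repeat on the second core what it did on the core of compound 1: the same change on two cores in this assay, a number 23 percentage points higher (beyond the scatter) from compound 1 to compound 2 and no change at the digits printed (within the scatter) from compound 3 to compound 4, 23 percentage points apart, beyond the scatter of two such steps.

Read along the other edge of the same four compounds, thiophen-2-yl in place of thiophen-3-yl gives a number 23 percentage points lower from compound 2 to compound 4 (beyond the scatter) with hydrogen on the chain, whereas the same swap changed nothing with trifluoromethyl there: the same change on two cores in this assay, no change at the digits printed (within the scatter) from compound 1 to compound 3 and a number 23 percentage points lower (beyond the scatter) from compound 2 to compound 4, 23 percentage points apart, beyond the scatter of two such steps.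

This shows that neither change can be carried over as a fixed increment in this set, since only compound 2 stands apart while compound 1, compound 3 and compound 4 print the same number; it does not show why the steps differ, and with a single set of four compounds, each tested at one concentration, it gives no rule for any other core.

The compounds shown leave open whether a methyl group or a longer chain in place of trifluoromethyl on that saturated chain carbon would behave like compound 2 or like compound 4. They also leave open whether a phenyl ring in place of the thiophene groups would keep the higher number of compound 2 when hydrogen stands on the chain.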